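A Longer Chain on Compound 3

The source may hold more compounds than are shown below. What is called first, only, known or untested is meant among the compounds shown, and "the series" means these compounds.

In a functional assay on EOL1 cells (Homo sapiens) for inhibition, read by fluorescence, with a stated time of 72 h (on this read-out higher numbers stand for weaker inhibition of growth and lower numbers for stronger inhibition of growth), compound 3 `CC(C)CCn1cnc2c(Nc3cccc(Cl)c3)nc(N[C@H]3CC[C@H](N)CC3)nc21` gives 60 nM and compound 1 `CC(C)=CCn1cnc2c(Nc3cccc(Cl)c3)nc(N[C@H]3CC[C@H](N)CC3)nc21` gives 80 nM, level within the scatter at the low end of the three numbers, while compound 2 `CCCCCCn1cnc2c(Nc3cccc(Cl)c3)nc(N[C@H]3CC[C@H](N)CC3)nc21` gives 310 nM. Compound 4 `CC(C)=CCC/C(C)=C/Cn1cnc2c(Nc3cccc(Cl)c3)nc(N[C@H]3CC[C@H](N)CC3)nc21` differs from compound 3 as follows: 2,6-dimethylhepta-1,5-dien-1-yl in place of isobutyl on a saturated chain carbon bound to an aromatic nitrogen. Isobutyl in place of 2-methylprop-1-en-1-yl changed little, a 1.3-fold lower number from compound 1 to compound 3 (0.12 log units; within the scatter). Pentyl in its place mattered more, a 3.9-fold higher number from compound 1 to compound 2 (0.59 log units; beyond the scatter), and a 5.2-fold lower number from compound 2 to compound 3 (0.71 log units; beyond the scatter) shows the same gap from the other side. Among the compounds with values here, compound 2 is the only guide to a longer group, so a modest rise, meaning weaker growth inhibition, is expected, with a 4.2-fold higher number from compound 3 to compound 4 (0.62 log units; beyond the scatter) as the estimated step in this assay. Compound 4 is estimated at 250 nM, within an expected range of 80 nM to 800 nM.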

Compound 4, concentration for 50% growth inhibition: 590 nM
Estimate against measurement, compound 4: 2.4-fold (0.37 log units) below; low and high end bracket the measured number.
By their numbers in this assay, from the lowest: compounds 3 and 1 (each within the scatter of the next); then compounds 2 and 4 (each within the scatter of the next).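

In this assay the step to the larger 2,6-dimethylhepta-1,5-dien-1-yl group is a 9.8-fold higher number from compound 3 to compound 4 (0.99 log units; beyond the scatter) and, counted from the other short chain, a 7.4-fold higher number from compound 1 to compound 4 (0.87 log units; beyond the scatter), so extra length at this position does not keep growth inhibition intact. Branching and double bonds do not separate it from the straight chain, as a 1.9-fold higher number from compound 2 to compound 4 (0.28 log units; within the scatter) stays within the scatter. Nothing at hand explains the loss.

Going by these compounds, whether length alone drives it, or the double bonds also count, stays open. So does how a benzyl group or a chain ending in an amine would behave here.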